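The source may report more compounds than this note shows. Statements on the series, on what has been measured and on what is new or still open speak of the compounds shown alone.

Compound 1 `CC(C)=CC[C@@H]1C[C@]2(CC=C(C)C)C(=O)[C@@](CC=C(C)C)(C(=O)C(C(=O)c3ccccc3)=C2O)C1(C)C`: 12 ug/mL
Compound 2 `CC(C)=CCC/C(C)=C/C[C@@H]1C[C@]2(CC=C(C)C)C(=O)[C@@](CC=C(C)C)(C(=O)C(C(=O)c3ccc(O)c(O)c3)=C2O)C1(C)C`: > 20 ug/mL

In a functional assay on HeLa cells (Homo sapiens) for inhibition (a lower number here means a stronger inhibitor, a higher number a weaker inhibitor), compound 1 gives 12 ug/mL. Compound 2 in this assay reaches only a limit of the measurement, > 20 ug/mL, so where it truly stands is not known; this is the situation noted as the limit of > 20 ug/mL in this assay, at which 1 of the 2 values shown sits. Compound 3 `CC(C)=CC[C@@H]1C[C@]2(CC=C(C)C)C(=O)[C@@](CC=C(C)C)(C(=O)C(C(=O)c3ccc(O)c(O)c3)=C2O)C1(C)C` has not yet been measured in this assay. It differs from compound 2 in one place: hydrogen in place of 3-methylbut-2-en-1-yl on a saturated chain carbon bound to a double-bonded chain carbon. No measured step of this kind exists among the compounds shown, so the step of a number no higher from compound 2 to compound 3 (the limit leaves the size open) is expected to be small, perhaps none beyond the scatter. Compound 3 is therefore estimated at 20 ug/mL, within 8 ug/mL to 50 ug/mL.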

Compound 3, half-maximal inhibitory concentration: 13.7 ug/mL
Beside the measured number, compound 3's estimate is 1.5-fold (0.16 log units) above it, and the stated range covers the measured number.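

In this assay, hydrogen in place of 3-methylbut-2-en-1-yl on the saturated chain carbon gives an at least 1.4-fold lower number from compound 2 to compound 3 (0.16 log units; that floor lies within the scatter). With 3,4-dihydroxyphenyl in place of phenyl on the carbonyl carbon, the result is a 1.1-fold higher number from compound 1 to compound 3 (0.06 log units; within the scatter), so with the shorter 3-methylbut-2-en-1-yl chain this change shows nothing beyond the scatter. The true size of the chain step stays unknown because compound 2 stands at a limit: the limit of > 20 ug/mL in this assay, at which 1 of the 3 values shown sits.

Still open, as far as these compounds go, is how an amine or a carboxylic acid in place of 3,4-dihydroxyphenyl would read. Also open, from the compounds shown here alone, is how the 3,7-dimethylocta-2,6-dien-1-yl chain would read with plain phenyl.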